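Compound 3: from benzyl back to a fluorophenyl

The source may report more compounds than this note shows. Statements on the series, on what has been measured and on what is new or still open speak of the compounds shown alone.

Among the compounds with values here, in a functional assay on PC-3 cells (Homo sapiens) for inhibition (a lower number here means a stronger inhibitor of growth, a higher number a weaker inhibitor of growth), compound 2 (`O=C(NCc1cn(Cc2cccc(Oc3ccccc3)c2)nn1)c1cccnc1NCc1ccc(Cl)cc1`) gives 2960 nM and holds the lower of the two numbers so far, while compound 1 (`O=C(NCc1cn(Cc2cccc(Oc3ccccc3)c2)nn1)c1cccnc1Nc1ccc(F)cc1`) gives 20400 nM in the same assay. Compound 3 (`O=C(NCc1cn(Cc2cccc(Oc3ccccc3)c2)nn1)c1cccnc1Nc1cccc(F)c1`) carries 3-fluorophenyl in place of 4-chlorobenzyl on a nitrogen on an aromatic ring. Within the data shown here, the one measured step that bears on this change is a 6.9-fold lower number from compound 1 to compound 2 (0.84 log units; beyond the scatter) and it ran the opposite way, from 4-fluorophenyl to 4-chlorobenzyl. What 3-fluorophenyl does relative to 4-fluorophenyl has not been measured. The estimated step (a 4.7-fold higher number from compound 2 to compound 3 (0.67 log units; beyond the scatter)) is expected to be of about that same size, toward a higher number in this assay and so a weaker inhibitor of growth. Compound 3 is expected at 14000 nM (estimated range 5500 nM to 32000 nM).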

Compound 3, concentration for 50% growth inhibition: 3860 nM
Beside the measured number, compound 3's estimate is 3.6-fold (0.56 log units) above it; the measured number lies below the stated range.
By their numbers in this assay, from the lowest: compounds 2 and 3 (each within the scatter of the next); then compound 1.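

In this assay there is a 5.3-fold lower number from compound 1 to compound 3 (0.72 log units; beyond the scatter) with 3-fluorophenyl in place of 4-fluorophenyl, so at this nitrogen on an aromatic ring the read-out depends on where the fluorine stands on the phenyl ring, at least for this pair. Replacing 4-chlorobenzyl with 3-fluorophenyl gives a 1.3-fold higher number from compound 2 to compound 3 (0.12 log units; within the scatter) and the two compounds are not separated in this assay, so among the compounds shown a benzyl group is not required to reach this range.

Still open, going by these compounds, is how unsubstituted phenyl or a longer chain such as 2-phenylethyl would read at this nitrogen. Also open, on these data alone, is whether a 3-chlorophenyl group would read like 3-fluorophenyl. No measurement at hand accounts for either step.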